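Bromo for fluoro with only a limit in hand

The compounds below may be only part of what the source reports. "The series", "measured", "known", "first", "only" and "open" are said of these compounds alone.

Measured so far:
Compound 1 `Nc1nc(NCCNc2ncc(-c3ncc[nH]3)c(-c3cc(F)ccc3Cl)n2)ccc1[N+](=O)[O-]` gives > 0.5 h as a limit in an ADME assay on microsomes from liver (Canis lupus familiaris) for metabolic stability; a lower number here means that the compound disappears faster, a higher number that the compound lasts longer
Compound 2 `Nc1nc(NCCNc2ncc(-c3ncc[nH]3)c(-c3ccc(Cl)cc3F)n2)ccc1[N+](=O)[O-]` gives > 0.5 h as a limit in this assay

Compound 2 has no exact half-life, and the picture so far is the limit of > 0.5 h in this assay, at which 2 of the 2 values shown sit, in both cases. Compound 3 `Nc1nc(NCCNc2ncc(-c3ncc[nH]3)c(-c3ccc(Cl)cc3Br)n2)ccc1[N+](=O)[O-]` differs from compound 2 by one change, (bromo in place of fluoro on an aromatic carbon), which puts bromo in place of fluoro on an aromatic carbon. Among the measured compounds shown here, the only measured step that bears on this is a step that the two limits leave unreadable from compound 1 to compound 2, so it offers no size to carry over. No direction can be read from it, and no step beyond the scatter is expected in this assay. The estimated step is a step that the limit leaves unreadable from compound 2 to compound 3, and this is only an expectation. Compound 3 is expected near 0.7 h, within a range from 0.35 h to 1.4 h, and it too may be reported only as a limit.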

Compound 3, half-life: > 0.5 h
Compound 3 was reported as a limit; the forecaster's own chance of this, stated with the estimate: 75%; the middle value is on the limit's open side.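

Compound 3 gives > 0.5 h, which is a limit and not a number. No step among compound 1, compound 2 and compound 3 can be read, as all three share one result: the limit of > 0.5 h in this assay, at which 3 of the 3 values shown sit.

From the compounds shown here alone, the exact half-lives of all three compounds, and so any effect of swapping fluoro for bromo, remain open.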